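Quinoline Anilides: Moving from a Substituted Phenyl to Pyridinyl

The source may hold more compounds than are shown below. What is called first, only, known or untested is meant among the compounds shown, and "the series" means these compounds.

The series shares one core, carried by compound 1 `COc1ccc2nc(C)cc(OCC(=O)Nc3ccccc3)c2c1` with an unsubstituted phenyl on the amide nitrogen. In a physicochemical assay for lipophilicity, read by HPLC, in phosphate buffer, measured as chromatographic lipophilicity, at pH 7.4 (on this read-out lower numbers stand for lower lipophilicity and higher numbers for higher lipophilicity), compound 1 gives 4.28. Compound 2 `COc1ccc2nc(C)cc(OCC(=O)Nc3cccc(C)c3)c2c1`, with a methyl in place of hydrogen on an aromatic carbon, gives 4.83, and the step of a number 0.55 log units higher from compound 1 to compound 2 (beyond the scatter). Compound 3 `COc1ccc2nc(C)cc(OCC(=O)Nc3cc(C)c(F)c(C)c3)c2c1` carries a 4-fluoro-3,5-dimethylphenyl on that nitrogen and gives 5.5, the highest of the three numbers, with a number 1.22 log units higher from compound 1 to compound 3 (beyond the scatter) and a number 0.67 log units higher from compound 2 to compound 3 (beyond the scatter).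

Compound 4 `COc1ccc2nc(C)cc(OCC(=O)Nc3cccnc3)c2c1` is the next step: pyridin-3-yl in place of 4-fluoro-3,5-dimethylphenyl on an amide-type nitrogen. Both steps leading up to compound 3 moved in the same direction as the carbon count on the aryl group grew, so taking away those methyls and the fluorine and bringing in a ring nitrogen should reverse that and go further, since compound 1 with a plain phenyl already sits well below compound 3. The expected step is therefore a number 2.20 log units lower from compound 3 to compound 4 (beyond the scatter), a large drop. For compound 4 the estimate in this assay is 3.3, with a range from 2.8 to 3.8.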

Compound 4, distribution coefficient: 2.46
Beside the measured number, compound 4's estimate is 0.84 log units above it; measured number outside the range, below it.
By their numbers in this assay, from the lowest: compound 4; then compound 1; then compound 2; then compound 3.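

Compounds 1, 2 and 3 showed this position only with carbon and fluorine added to a phenyl ring, and each such step raised the number; compound 4 shows that the read-out in this assay can also fall sharply here, with pyridin-3-yl on the amide-type nitrogen giving the lowest number of the four (a number 3.04 log units lower from compound 3 to compound 4 (beyond the scatter); a number 2.37 log units lower from compound 2 to compound 4 (beyond the scatter); a number 1.82 log units lower from compound 1 to compound 4 (beyond the scatter)). Among the compounds shown here, the last of these steps is the most direct comparison, as pyridin-3-yl simply replaces unsubstituted phenyl, and it is large, whereas the single methyl of compound 2 gave a modest step. Nothing available bears on the reason for a step of this size.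

The compounds shown leave open how pyridin-2-yl or pyridin-4-yl would read at this position. They also leave open whether a methyl or a fluorine on pyridin-3-yl would raise the number as those groups did on phenyl.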